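The source may report more compounds than this note shows. Statements on the series, on what has been measured and on what is new or still open speak of the compounds shown alone.

Measured compounds in an ADME assay on BCBL1 cells (Homo sapiens) for cytotoxicity, with a stated time of 7 days; a higher number here means that more compound is tolerated, a lower number that less compound is tolerated:

- compound 1, `CC(C)CNc1nc(N)nc2c1ncn2/C=C1/CC1(CO)CO`: > 20000 nM (a limit of the assay)
- compound 2, `CCCCCOc1nc(N)nc2c1ncn2/C=C1/CC1(CO)CO`: > 20000 nM (a limit of the assay)
- compound 3, `CCCCNc1nc(N)nc2c1ncn2/C=C1/CC1(CO)CO`: > 20000 nM (a limit of the assay)

Compound 3 gives only a limit in this assay; for compound 3 the half-maximal cytotoxic concentration is > 20000 nM, a limit and not a number. The other two values shown are limits as well, so that compound 3 cannot be placed relative to compound 1 or compound 2 on these numbers. The steps among the measured compounds, a step that the two limits leave unreadable from compound 1 to compound 2, a step that the two limits leave unreadable from compound 1 to compound 3 and a step that the two limits leave unreadable from compound 2 to compound 3, are all unreadable, because all three values sit at the limit of > 20000 nM in this assay, at which 3 of the 3 values shown sit.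

Compound 4, `CCCCCCSc1nc(N)nc2c1ncn2/C=C1/CC1(CO)CO`, is not yet measured. Compared with compound 3 the change is hexylsulfanyl in place of butylamino on an aromatic carbon. Among the compounds with values here, no measured step bears readably on this change; what is shared is that every value shown sits at the limit of > 20000 nM in this assay, at which 3 of the 3 values shown sit.

Compound 4 is therefore expected to give a limit again in this assay, with an expected step that the limit leaves unreadable from compound 3 to compound 4 of no readable size. The estimate for compound 4 is 30000 nM, between 10000 nM and 100000 nM.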

Compound 4, half-maximal cytotoxic concentration: > 20000 nM
Compound 4 was reported as a limit (the forecaster's own chance of this, stated with the estimate: 80%); the middle value is on the limit's open side.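

In this assay compound 4 gives > 20000 nM, a limit and not a number. No step to compound 4 from compound 1, compound 2 or compound 3 can be read, because all values coincide: the limit of > 20000 nM in this assay, at which 4 of the 4 values shown sit.

The compounds shown leave open whether the four differ at all in cytotoxicity, and at what concentration any of them becomes cytotoxic.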